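From methanesulfonamido to hydroxymethyl on a carbonyl carbon

This account rests on a few compounds, and the source may have more. Where it says the series, first, only, none or still open, it means among the compounds named here.

Values in a functional assay on the whole organism for inhibition, with Rattus norvegicus as the target (a higher number here means that more compound is needed for the effect, a lower number that less compound is needed), follow.
- Compound 1 `CC(C)c1ccc(OC(C)(Cc2ccc(C(F)(F)F)cc2)C(=O)O)cc1` gives < 5 mg/kg as a limit
- Compound 2 `CCCc1ccc(CC(C)(Oc2ccc(C(C)C)cc2)C(=O)O)cc1` gives 0.5 mg/kg as a number
- Compound 3 `CC(C)c1ccc(OC(C)(Cc2ccc(Cl)cc2)C(=O)NS(C)(=O)=O)cc1` gives 5 mg/kg as a number
- Compound 4 `CC(C)c1ccc(OC(C)(Cc2ccc(Cl)cc2)C(=O)CO)cc1` is not yet measured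

Compound 3 at 5 mg/kg has the higher of the two true numbers, and compound 2 at 0.5 mg/kg lies lower by more than the scatter. Compound 4 carries hydroxymethyl in place of methanesulfonamido on a carbonyl carbon and keeps the shared core. Among the compounds with values here, the only measured step that the limit leaves unreadable from compound 1 to compound 2 lies on an aromatic carbon and rests on the limit of < 5 mg/kg in this assay, at which 1 of the 3 values shown sits, with no readable size, so it does not bear on this change. Within the data shown here, no measured step gives a size for this swap, so a wide range is kept. The estimated change a 1.6-fold higher number from compound 3 to compound 4 (0.20 log units; within the scatter) is expected to stay within the scatter, with no firm direction. For compound 4 the estimated value is 8 mg/kg within an expected range from 1.5 mg/kg to 40 mg/kg as a rough guide.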

Compound 4, dose for half-maximal effect: > 10 mg/kg
Compound 4 gave a limit, no number; the forecaster's own chance of this, stated with the estimate: 25%; at least 1.2-fold (0.09 log units) between middle value and limit.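

At this carbonyl carbon, in this assay, hydroxymethyl in place of methanesulfonamido gives an at least 2.0-fold higher number from compound 3 to compound 4 (0.30 log units; that floor lies within the scatter). Within the data shown here, this is the first step with any readable size for a change at this place, but it gives only a floor and the true size stays unknown. The reading for compound 4 is a limit and not a number: the limit of > 10 mg/kg in this assay, at which 1 of the 4 values shown sits.

As far as these compounds go, how far compound 4 actually lies from compound 3 remains open. Also open, from the compounds shown here alone, is how other groups on this carbonyl carbon, such as aminomethyl or methoxymethyl, would read in this assay.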